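A few compounds are considered here, and "the series" means these few. Any claim that something is new, unique, unknown or untested is made for them only; others in the source may bear on it.

In a functional assay on DU-145 cells (Homo sapiens) for inhibition, read by trypan blue exclusion, with a stated time of 72 h (a higher number here means a weaker inhibitor, a lower number a stronger inhibitor), compound 3 `COc1ccc(Nc2ncc3cc(S(=O)(=O)c4ccc(Cl)cc4)c(=O)n(C)c3n2)cc1` gives 30000 nM and stands level with compound 1 `Cn1c(=O)c(S(=O)(=O)Cc2ccc(F)cc2)cc2cnc(Nc3ccc4[nH]ccc4c3)nc21` at 30000 nM at the digits shown, while compound 2 `COc1ccc(S(=O)(=O)c2cc3cnc(Nc4ccc5[nH]ccc5c4)nc3n(C)c2=O)cc1` gives 500 nM and lies far lower than both. Compound 4 `Cn1c(=O)c(S(=O)(=O)c2ccc(Cl)cc2)cc2cnc(Nc3ccc4[nH]ccc4c3)nc21`, not yet measured, differs from compound 3 in one place, with 1H-indol-5-yl in place of 4-methoxyphenyl on a nitrogen on an aromatic ring. Among the compounds with values here, no measured step makes this swap. The only one available, a 60-fold lower number from compound 1 to compound 2 (1.78 log units; beyond the scatter) and thus large, changes the group on the sulfonyl sulfur instead, but it ends at compound 2, which carries the same 1H-indol-5-yl group. That group alone does not settle the outcome, since compound 1 also carries it and gives 30000 nM in the same test. Compound 4 also has an aromatic ring on the sulfonyl sulfur, like compound 2 at 500 nM and unlike compound 1. A large downward step is therefore expected in this assay and the estimate puts it at a 30-fold lower number from compound 3 to compound 4 (1.48 log units; beyond the scatter) beyond the scatter. Compound 4 is estimated at 1000 nM within an expected range of 200 nM to 8000 nM pending measurement.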

Compound 4, half-maximal inhibitory concentration: 250 nM
For compound 4 the middle estimate is 4.0-fold (0.60 log units) above the measured one, within the range that was stated.
By their numbers in this assay, from the lowest: compounds 4 and 2 (each within the scatter of the next); then compounds 1 and 3 (each within the scatter of the next).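

In this assay, within the data shown here, the change from (4-methoxyphenyl)amino to (1H-indol-5-yl)amino at this nitrogen on an aromatic ring, read on its own with 4-chlorophenyl held on the sulfonyl sulfur, gives a large step (a 120-fold lower number from compound 3 to compound 4 (2.08 log units; beyond the scatter)), which no earlier pair had isolated. With 1H-indol-5-yl in place, chloro and methoxy on the aromatic ring on the sulfonyl sulfur cannot be told apart (a 2.0-fold lower number from compound 2 to compound 4 (0.30 log units; within the scatter)), while 4-chlorophenyl in place of 4-fluorobenzyl gives a second large step (a 120-fold lower number from compound 1 to compound 4 (2.08 log units; beyond the scatter)), so both the group on the nitrogen and the group on the sulfur weigh heavily in this series. Nothing measured here explains either step.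

Open, on these data alone, is how a 1-methyl-1H-indol-5-yl group on this nitrogen would compare with 1H-indol-5-yl. Also open, as far as these compounds go, is whether an amine or a carboxylic acid on the aromatic ring on the sulfonyl sulfur would keep the numbers at this level in this assay.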